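Benzylsulfanyl on the ribose sugar: outlook for compound 4

The source may hold more compounds than are shown below. What is called first, only, known or untested is meant among the compounds shown, and "the series" means these compounds.

The set comprises compound 1 `Cc1nsc2c1nc(SCc1ccccc1)n2[C@H]1C[C@H](O)[C@@H](CO)O1`, compound 2 `Cc1nsc2c1ncn2[C@@H]1O[C@H](CO)[C@@H](O)[C@@H]1O` and compound 3 `CSc1nc2c(C)nsc2n1[C@@H]1O[C@H](CO)[C@@H](O)[C@@H]1O`, all read in a functional assay on KB cells (Homo sapiens) for antiproliferative activity; on this read-out higher numbers stand for weaker inhibition and lower numbers for stronger inhibition. In this assay compound 1 gives > 100000 nM, which is a limit of the assay and not a number. In this assay compound 2 gives > 100000 nM, again only a limit. In this assay compound 3 gives > 100000 nM, also a limit. Compound 3 thus stands at the limit and cannot be placed relative to compound 1 or compound 2; all three values sit at the limit of > 100000 nM in this assay, at which 3 of the 3 values shown sit. Among the compounds with values here, the single one-place step in the set, a step that the two limits leave unreadable from compound 2 to compound 3, stays unreadable for that reason, so no measured step of known size bears on the next change.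

Compound 4 `Cc1nsc2c1nc(SCc1ccccc1)n2[C@@H]1O[C@H](CO)[C@@H](O)[C@@H]1O` follows from compound 3 by phenyl in place of hydrogen on a saturated chain carbon bound to a sulfur. Compound 1 carries the same benzylsulfanyl group on a different sugar and in this assay gives a limit, > 100000 nM. Against that background the expected step, a number no higher from compound 3 to compound 4 (the limit leaves the size open), is estimated as none beyond the scatter. Compound 4 is therefore estimated at 100000 nM, within a range of 30000 nM to 300000 nM, and is most likely to be reported again only as a limit.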

Compound 4, half-maximal inhibitory concentration: > 100000 nM
Compound 4: only a limit was reported; the forecaster's own chance of this, stated with the estimate: 85%; the middle value lies on the limit itself.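

In this assay compound 4 gives > 100000 nM, which is a limit and not a number. Within the data shown here, no step among compound 1, compound 2, compound 3 and compound 4 can be read, because every value stands at the same limit: the limit of > 100000 nM in this assay, at which 4 of the 4 values shown sit. The compounds shown leave open how large any of these changes is, and whether any substituent on the shared core gives a readable value.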